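The compounds below may be only part of what the source reports. "The series", "measured", "known", "first", "only" and "open" are said of these compounds alone.

Measured so far in a functional assay on HepG2 cells (Homo sapiens) for cytotoxicity, read by MTT assay, with a stated time of 48 h; a higher number here means a weaker inhibitor, a lower number a stronger inhibitor:
compound 1 `CCCCCCCCCCCCNC(=O)[C@@H](NC(=O)c1ccccc1)[C@@H](C)O` gives > 400000 nM, a limit of the assay;
compound 2 `CCCCCCCCCCCCNC(=O)[C@@H](NC(=O)c1cc2ccccc2o1)[C@@H](C)O` gives 22900 nM;
compound 3 `CCCCCCCCCCCCNC(=O)[C@@H](NC(=O)c1cc2ccccc2[nH]1)[C@@H](C)O` gives 12000 nM.

Compound 3 has the lowest of the two numbers, with compound 2 at a 1.9-fold lower number from compound 2 to compound 3 (0.28 log units; within the scatter). Both sit far from the limit of compound 1 (the limit of > 400000 nM in this assay, at which 1 of the 3 values shown sits), as an at least 17-fold lower number from compound 1 to compound 2 (1.24 log units; beyond the scatter) and an at least 33-fold lower number from compound 1 to compound 3 (1.52 log units; beyond the scatter) show.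

Compound 4 `CCCCCCCCCCCCCCCCCCNC(=O)[C@@H](NC(=O)c1cc2ccccc2[nH]1)[C@@H](C)O` differs from compound 3 by hexyl in place of hydrogen on a saturated chain carbon, ten or more bonds along the chain from an amide-type nitrogen. Among the compounds with values here, none of the measured steps touches the chain; all three exchange the group on the carbonyl carbon. So no measured step bears on this change, and no step beyond the scatter can be expected from the numbers shown. Compound 4 is therefore estimated at 10000 nM, between 3000 nM and 40000 nM, which means an expected step of a 1.2-fold lower number from compound 3 to compound 4 (0.08 log units; within the scatter).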

Compound 4, half-maximal inhibitory concentration: 89400 nM
Compound 4: the middle estimate sits 8.9-fold (0.95 log units) below what was measured; the whole stated range lies below it.
By their numbers in this assay, from the lowest: compounds 3 and 2 (each within the scatter of the next); then compound 4. At a limit, above all of these: compound 1.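

In this assay, within the data shown here, the earlier compounds changed only the group on the carbonyl carbon, whereas this pair shows that the chain on the amide nitrogen also matters: hexyl in place of hydrogen gives a 7.5-fold higher number from compound 3 to compound 4 (0.87 log units; beyond the scatter). With the indol-2-yl group held fixed, the longer chain goes with the higher number, though this rests on one pair. Nothing shown gives a cause for this step.

The compounds shown leave open how a shorter chain, such as octyl, would read. They also leave open whether the same hexyl change would act alike with 1-benzofuran-2-yl on the carbonyl carbon.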